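Cytotoxicity of a bromochromene pair and a predicted analogue

The compounds below may be only part of what the source reports. "The series", "measured", "known", "first", "only" and "open" are said of these compounds alone.

Compound 1 `COC(=O)C1=C(N)Oc2ccc(Br)cc2C1CC(=O)c1ccc(Br)cc1`: 43.2%
Compound 2 `COc1cccc(C(=O)CC2C(C#N)=C(N)Oc3ccc(Br)cc32)c1`: 43.7%

Of the compounds shown here, two share the core of compound 1 and have been measured in an ADME assay on MCF-10A cells (Homo sapiens) for cytotoxicity, read by sulforhodamine B assay, with a stated time of 72 h, tested at 30 uM; a lower number here means a weaker effect, a higher number a stronger effect of the compound at the concentration tested. In this assay compound 1 gives 43.2%, and in the same assay compound 2 gives 43.7%. The two numbers lie within the usual scatter of each other, so the data do not separate compound 2 from compound 1; compound 2 stands among two numbers that cannot be told apart. For the measured compounds named here, no step between these two measured compounds is recorded, and only their two values are available.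

Compound 3 `N#CC1=C(N)Oc2ccc(Br)cc2C1CC(=O)c1ccc(Br)cc1` has not yet been measured. It differs from compound 2 in one place: 4-bromophenyl in place of 3-methoxyphenyl on a carbonyl carbon. The 4-bromophenyl on a carbonyl carbon is already present in compound 1, whose number sits close to that of compound 2. For this reason the step from compound 2 to compound 3 in this assay is expected to be small, no larger than the scatter, in either direction, at a number 0.3 percentage points higher from compound 2 to compound 3 (within the scatter). Compound 3 is therefore estimated to give 44% in this assay, with a range from 30% to 58%.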

Compound 3, a percentage reported as activity, at one concentration (the size of the read-out at that concentration, not a potency): 43.6%
Beside the measured number, compound 3's estimate is 0.4 percentage points above it, and the stated range covers the measured number.
By their numbers in this assay, from the lowest: compounds 1, 3 and 2 (each within the scatter of the next).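

For the compounds shown here, compound 3 gives the first readable single-place steps in this set, tying it to both earlier compounds. In this assay, the step for 4-bromophenyl in place of 3-methoxyphenyl on a carbonyl carbon is a number 0.1 percentage points lower from compound 2 to compound 3 (within the scatter), and the step for cyano in place of methoxycarbonyl on a double-bonded ring carbon is a number 0.4 percentage points higher from compound 1 to compound 3 (within the scatter), so neither exchange separates the compounds at the concentration tested. No measurement at hand offers an explanation for this lack of separation.

The compounds shown cover only two aryl groups on the carbonyl carbon and only two groups on the double-bonded ring carbon, so they do not show whether either place would tolerate a very different group. An amine or a longer chain in place of the aryl group, or a carboxylic acid in place of the cyano group, might give a step beyond the scatter or might leave the read-out just as close to those of these three compounds.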